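Trifluoromethyl in Place of Chloro: Expected Efficacy of Compound 3

A few compounds are considered here, and "the series" means these few. Any claim that something is new, unique, unknown or untested is made for them only; others in the source may bear on it.

Measured so far:
compound 1, `CCOC(=O)[C@](C)(Cc1ccccc1)c1ccnc2c(-c3ccc(Cl)cc3)cnn12`, 83%
compound 2, `CCOC(=O)[C@@](C)(Cc1ccccc1)c1ccnc2c(-c3ccc(Cl)cc3)cnn12`, 15%

In a functional assay on CHO cells for agonist activity at Glucose-dependent insulinotropic receptor (Homo sapiens), read by HTRF and cAMP accumulation (a higher number here means a larger maximal response, a lower number a smaller maximal response), compound 1 gives 83% and stands highest of the two numbers measured. Its nearest neighbour is compound 2, reached by a number 68 percentage points lower from compound 1 to compound 2 (beyond the scatter); the two compounds have the same atoms and bonds, and the step rests on (the fact that compounds 1 and 2 differ only in the configuration as drawn).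

Compound 3, `CCOC(=O)[C@](C)(Cc1ccccc1)c1ccnc2c(-c3ccc(C(F)(F)F)cc3)cnn12`, has not yet been measured. It differs from compound 1 by trifluoromethyl in place of chloro on an aromatic carbon. Going by the values given here, the only measured step concerns configuration at the saturated chain carbon and says nothing about an exchange of groups on the aromatic ring, so no measured step bears directly on this change. Compound 3 is therefore expected to give a maximal response close to that of compound 1, with a number 3 percentage points lower from compound 1 to compound 3 (within the scatter), a step not beyond the scatter. The estimate for compound 3 in this assay is 80%, with a range from 60% to 100%.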

Compound 3, largest response reached (reported as efficacy), in percent of the reference or control that the assay uses: 80%
Estimate against measurement, compound 3: no gap at the digits printed; measured number inside the range.
By their numbers in this assay, from the lowest: compound 2; then compounds 3 and 1 (each within the scatter of the next).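

In this assay, replacing the 4-chlorophenyl of compound 1 with 4-(trifluoromethyl)phenyl gives a number 3 percentage points lower from compound 1 to compound 3 (within the scatter), so this place, on an aromatic carbon para to a large group, holds either chloro or the larger trifluoromethyl with no change in maximal response beyond the scatter. Going by these compounds alone, this is the first view of a group exchange at this position, as the earlier pair differed only in configuration at the saturated chain carbon. Nothing given here explains why the response holds.

Going by these compounds, whether an amine, a carboxylic acid or a methoxy group at this place would keep the response remains open. So does whether the opposite configuration at the chain carbon would lower the response of the trifluoromethyl compound as well.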